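Adding a Carboxyethyl Chain to a Compound at the Limit

This account rests on a few compounds, and the source may have more. Where it says the series, first, only, none or still open, it means among the compounds named here.

Compound 1, `Cc1ccccc1-c1noc(-c2ccc(C3CCCCC3)cc2)n1`, was tested in a functional assay on CHO cells with sphingosine 1-phosphate receptor 2 (Homo sapiens) as the target, read by GTPgammaS binding; a higher number here means that more compound is needed for the effect, a lower number that less compound is needed. Compound 1 gives only a limit there, > 10000 nM, so no number is known for it. Compound 2, `Cc1cc(CCC(=O)O)ccc1-c1noc(-c2ccc(OC(C)C)c(F)c2)n1`, likewise reaches only the limit of > 10000 nM in this assay. Compound 3, `Cc1cc(CCC(=O)O)ccc1-c1noc(-c2ccc(OC(C)C(F)(F)F)c(C#N)c2)n1`, also stops at the limit, > 10000 nM. Going by the values given here, all three measured values therefore sit together at the limit of > 10000 nM in this assay, at which 3 of the 3 values shown sit, and no step between measured compounds can be read from them.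

Compound 4, `Cc1cc(CCC(=O)O)ccc1-c1noc(-c2ccc(C3CCCCC3)cc2)n1`, is not yet measured. It differs from compound 1 by 2-carboxyethyl in place of hydrogen on an aromatic carbon. Compound 2 already carries this 2-carboxyethyl chain and still sits at its limit of > 10000 nM. Compound 3 carries it too and again gives > 10000 nM. Nothing in these values points toward a gain. The expected step from compound 1 to compound 4 in this assay is a step that the limit leaves unreadable from compound 1 to compound 4, meaning no change beyond the scatter. Compound 4 is therefore estimated at 20000 nM, with a range from 5000 nM to 100000 nM, and the assay will most likely again report only a limit.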

Compound 4, half-maximal effective concentration: > 10000 nM
Compound 4: a limit, no number; the forecaster's own chance of this, stated with the estimate: 85%; the middle value does not contradict the limit.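

In this assay compound 4 gives > 10000 nM, which is a limit and not a number. Compound 1 also stops at a limit, so no step between compound 1 and compound 4 can be read: the limit of > 10000 nM in this assay, at which 4 of the 4 values shown sit.

The compounds shown leave open whether 2-carboxyethyl in place of hydrogen changes the concentration needed in this assay at all.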